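Pyridazine for methoxypyridine: solubility outlook for compound 4

The source may hold more compounds than are shown below. What is called first, only, known or untested is meant among the compounds shown, and "the series" means these compounds.

Compound 1 `FC(F)(F)Oc1ccc(-c2nc3cnc(Nc4ccccn4)cc3[nH]2)cc1`: < 5000 nM
Compound 2 `COc1ccnc(Nc2cc3[nH]c(-c4cccc(C(F)(F)F)c4)nc3cn2)c1`: < 5000 nM
Compound 3 `FC(F)(F)c1cccc(-c2nc3cnc(Nc4ncccn4)cc3[nH]2)c1`: < 5000 nM

In a physicochemical assay for solubility, using the shake flask method, in phosphate buffer, measured as kinetic solubility, with a stated time of 20 h, at pH 6.5 (on this read-out lower numbers stand for lower solubility and higher numbers for higher solubility), compound 1 gives < 5000 nM, which is a limit of the assay and not a number. Compound 2 gives < 5000 nM, again only a limit. Compound 3 gives < 5000 nM, also a limit. So compound 2 stands at the lower edge of what this assay reports, and no measured value places it more precisely; indeed (the limit of < 5000 nM in this assay, at which 3 of the 3 values shown sit).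

Going by the values given here, the only measured step that touches the same part of the molecule, a step that the two limits leave unreadable from compound 2 to compound 3, cannot be sized, because both of its ends are limits. Compound 4 `FC(F)(F)c1cccc(-c2nc3cnc(Nc4cccnn4)cc3[nH]2)c1` differs from compound 2 by pyridazin-3-yl in place of 4-methoxypyridin-2-yl on a nitrogen on an aromatic ring. With no readable step to go on, the change from compound 2 to compound 4 is expected to be a step that the limit leaves unreadable from compound 2 to compound 4, most likely leaving compound 4 at the same limit. Compound 4 is therefore estimated at 3000 nM, with a range from 500 nM to 9000 nM.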

Compound 4, solubility: < 5000 nM
Compound 4: no number, only a limit; the forecaster's own chance of this, stated with the estimate: 75%; the middle value lies beyond the limit too.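

In this assay compound 4 gives < 5000 nM, a limit of the assay and not a number. The steps to compound 4 from compound 2 and from compound 3 cannot be read, as every value here is a limit: the limit of < 5000 nM in this assay, at which 4 of the 4 values shown sit.

From the compounds shown here alone, the true solubilities of compound 2, compound 3 and compound 4, and how they compare, remain open.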